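This account rests on a few compounds, and the source may have more. Where it says the series, first, only, none or still open, it means among the compounds named here.

Of the compounds shown here, three sharing one core have been measured so far. Compound 1 `COc1ccc(-c2cn3ccnc3c(-c3ccc4ncn(C5CCCCC5)c4c3)n2)cc1` gives 77.8% in a functional assay on SW-620 cells (Homo sapiens) for inhibition, read by sulforhodamine B assay, with a stated time of 48 h, tested at 10 uM; on this read-out higher numbers stand for more inhibition at the one concentration tested (going by the name of the read-out) and lower numbers for less inhibition. Compound 2 `O=Cc1ccc(-c2cn3ccnc3c(-c3ccc4ncn(C5CCCCC5)c4c3)n2)cc1` gives 4.21% in this assay, and compound 3 `Fc1ccc(-c2cn3ccnc3c(-c3ccc4ncn(C5CCCCC5)c4c3)n2)cc1` gives 8.38%. On these three numbers compound 3 stands second highest, with compound 2 within the usual scatter of it and compound 1 far above it: the step of a number 69.4 percentage points lower from compound 1 to compound 3 (beyond the scatter) was large, as was a number 73.6 percentage points lower from compound 1 to compound 2 (beyond the scatter), while a number 4.2 percentage points higher from compound 2 to compound 3 (within the scatter) lay within the scatter.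

Compound 4 `Clc1ccc(-c2cn3ccnc3c(-c3ccc4ncn(C5CCCCC5)c4c3)n2)cc1` is not yet measured. It differs from compound 3 in one place: chloro in place of fluoro on an aromatic carbon. Going by the values given here, no measured step swaps one halogen for another, so the expectation rests on neighbours: compound 2 and compound 3, carrying a formyl or a fluoro group on the same aromatic carbon, gave numbers within the scatter of each other, and only the methoxy group of compound 1 stood out. A step of no size beyond the scatter is therefore expected, a number 3.6 percentage points higher from compound 3 to compound 4 (within the scatter). For compound 4 the estimate in this assay is 12%, with a range from 0% to 40%.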

Compound 4, a percentage reported as inhibition, at one concentration (the size of the read-out at that concentration, not a potency): 14%
Beside the measured number, compound 4's estimate is 2 percentage points below it; the range from low to high includes it.
By their numbers in this assay, from the lowest: compounds 2, 3 and 4 (each within the scatter of the next); then compound 1.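

The swap of one halogen for another on this aromatic carbon gives a number 5.6 percentage points higher from compound 3 to compound 4 (within the scatter) in this assay and so makes no readable difference, and the comparison with formyl gives a number 9.8 percentage points higher from compound 2 to compound 4 (within the scatter) as well. Fluoro, chloro and formyl now form one low group of three quite different substituents, while the comparison with methoxy, a number 63.8 percentage points lower from compound 1 to compound 4 (beyond the scatter) on the same carbon, confirms that compound 1 stands alone far above all of them. Nothing available here explains why methoxy differs from the other groups.

Still open, as far as these compounds go, is whether the high number belongs to methoxy alone or would also appear with a close relative such as ethoxy or hydroxyl. A dimethylamino group or a plain methyl group at this position would help to show how specific the effect is.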